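The source may hold more compounds than are shown below. What is called first, only, known or untested is meant among the compounds shown, and "the series" means these compounds.

In a functional assay on KBVIN cells (Homo sapiens) for antiproliferative activity, read by sulforhodamine B assay, with a stated time of 48 h (a higher number here means a weaker inhibitor of growth, a lower number a stronger inhibitor of growth), compound 2 `N#Cc1ccc(Nc2nc(NC3CCCC3)c3ccccc3n2)cc1` gives > 31300 nM, which is a limit and not a number. Compound 2 therefore stands at the limit of > 31300 nM in this assay, at which 1 of the 3 values shown sits.

Compound 4 `N#Cc1ccc(Nc2nc(NCCCO)c3ccccc3n2)cc1` keeps the nitrile of compound 2 but has 3-hydroxypropyl in place of cyclopentyl on a nitrogen on an aromatic ring.

Among the compounds with values here, no measured step makes this exchange. The only one is an at least 1.5-fold lower number from compound 2 to compound 3 (0.19 log units; that floor lies within the scatter), and it concerns carboxy in place of cyano on an aromatic carbon, with the cyclopentylamino group untouched. Compound 3 `O=C(O)c1ccc(Nc2nc(NC3CCCC3)c3ccccc3n2)cc1` gives 19800 nM in this assay, which shows that this series can return a real number in this range. The closest guide is compound 1 `COc1ccc(Nc2nc(NCCCO)c3ccccc3n2)cc1`, which carries the same 3-hydroxypropyl group on that nitrogen and gives 17100 nM.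

On that basis the expected change is small and points toward a lower number, without clearly leaving the scatter: an at least 1.4-fold lower number from compound 2 to compound 4 (0.15 log units; that floor lies within the scatter). For compound 4 the estimate is 22000 nM, with an expected range from 10000 nM to 40000 nM.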

Compound 4, concentration for 50% growth inhibition: 4310 nM
Compound 4: middle estimate off by 5.1-fold (0.71 log units), on the high side, outside the stated range (below it).
By their numbers in this assay, from the lowest: compound 4; then compounds 1 and 3 (each within the scatter of the next). At a limit, above all of these: compound 2.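

In this assay, within the data shown here, 3-hydroxypropyl in place of cyclopentyl on that nitrogen, with the nitrile kept, gives an at least 7.2-fold lower number from compound 2 to compound 4 (0.86 log units; beyond the scatter), the first step at this position that can be read, and it lies beyond the scatter. On these data alone, compound 2 is held only as a limit, so the true size of this step stays unknown: the limit of > 31300 nM in this assay, at which 1 of the 4 values shown sits. With 3-hydroxypropyl kept, the group on the aromatic carbon also counts, since cyano in place of methoxy gives a 4.0-fold lower number from compound 1 to compound 4 (0.60 log units; beyond the scatter).

As far as these compounds go, it remains open whether a longer chain, or a chain ending in an amine instead of the hydroxyl, would serve that nitrogen as well. From the compounds shown here alone, it is also open how carboxy on the aromatic carbon would behave alongside 3-hydroxypropyl.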